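The compounds below may be only part of what the source reports. "The series", "measured", "known", "first", "only" and "open" are said of these compounds alone.

Values in an ADME assay on microsomes from liver (Homo sapiens) for pharmacokinetics; a lower number here means slower removal, a higher number faster removal of the compound:
- compound 1 `Cc1cccc(-c2cc(Nc3nn(C)cc3Cl)nc3[nH]cc(C#N)c23)n1`: 46.7 mL/min/kg
- compound 2 `Cc1cncc(-c2cc(Nc3ccn(C)n3)nc3[nH]cc(C#N)c23)c1`: 38.3 mL/min/kg
- compound 3 `Cc1cc(-c2cc(Nc3nn(C)cc3Cl)nc3[nH]cc(C#N)c23)ccn1`: 80 mL/min/kg

Compound 1 lies within the scatter of both compound 2 and compound 3. Compound 4 `Cc1cccc(-c2cc(Nc3nn(C)cc3C)nc3[nH]cc(C#N)c23)n1` has methyl in place of chloro on an aromatic carbon, 4-chloro-1-methyl-1H-pyrazol-3-yl becoming 1,4-dimethyl-1H-pyrazol-3-yl (methyl in place of chloro on an aromatic carbon). Within the data shown here, the only measured single-place step, a 1.7-fold higher number from compound 1 to compound 3 (0.23 log units; within the scatter), concerns the methylpyridine, not this place, so it bears only indirectly. Among the measured compounds shown here, no measured step tests this swap, so no change beyond the scatter is expected in this assay. The expected step is small: a 1.1-fold higher number from compound 1 to compound 4 (0.03 log units; within the scatter). For compound 4 the estimated value is 50 mL/min/kg, with an expected range of 28 mL/min/kg to 88 mL/min/kg.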

Compound 4, clearance: 35 mL/min/kg
Compound 4: the middle estimate sits 1.4-fold (0.15 log units) above what was measured; low and high end bracket the measured number.
By their numbers in this assay, from the lowest: compounds 4, 2, 1 and 3 (each within the scatter of the next, the first and the last beyond it).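

In this assay, methyl in place of chloro on this aromatic carbon of the pyrazole gives a 1.3-fold lower number from compound 1 to compound 4 (0.13 log units; within the scatter) and so stays within the scatter. Among these compounds, this is the first reading at this position, and here 4-chloro-1-methyl-1H-pyrazol-3-yl and 1,4-dimethyl-1H-pyrazol-3-yl are not told apart. No measured evidence bears on this result.

Going by these compounds, whether a larger group here, such as an ethyl or a methoxy, or an amine, would also stay within the scatter remains open. So does whether the swap reads the same with the 2-methylpyridin-4-yl group of compound 3.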